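The compounds below may be only part of what the source reports. "The series", "measured", "known", "first", "only" and "open" are said of these compounds alone.

Measured so far in a toxicity assay on microsomes from liver (Homo sapiens) for metabolic stability, read by LC-MS, using NADPH, tested at 1 uM; on this read-out higher numbers stand for fast clearance and lower numbers for slow clearance:
- compound 1 `C[C@@H]1CN(c2sc(C(F)(F)F)nc2-c2nc3ccccc3[nH]2)CCN1C(=O)Cn1cnc2cccnc21`: 89 mL.min-1.g-1
- compound 2 `CCOc1ncc(-c2nc(C(F)(F)F)sc2N2CCN(C(=O)Cn3nc(C)cc3C)[C@H](C)C2)cn1`: 184 mL.min-1.g-1
- compound 3 `COc1ncc(-c2nc(C(F)(F)F)sc2N2CCN(C(=O)Cn3nc(C)nc3C)[C@H](C)C2)cn1`: < 10 mL.min-1.g-1

Compound 3 gives < 10 mL.min-1.g-1, which is a limit of the assay and not a number. The other two compounds both returned actual numbers, so compound 3 sits alone at the slow-clearance end of this small set.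

The next compound, compound 4 `Cc1nc(C)n(CC(=O)N2CCN(c3sc(C(F)(F)F)nc3-c3cnc(C(C)(C)C)nc3)C[C@H]2C)n1`, keeps the rest of compound 3 and changes one group: tert-butyl in place of methoxy on an aromatic carbon, between two ring nitrogen atoms and para to a large group (tert-butyl in place of methoxy on an aromatic carbon). In other words, 2-methoxypyrimidin-5-yl becomes 2-(tert-butyl)pyrimidin-5-yl.

Among the measured compounds shown here, no pair of measured compounds isolates this change, so any forecast rests on thin evidence. Compound 1 gives 89 mL.min-1.g-1. Compound 2 gives 184 mL.min-1.g-1. These two values show that the shared core does not by itself ensure slow clearance, and they suggest that a swap on this part of the molecule could leave the low end. The expected change is a rise toward faster clearance, beyond the usual scatter, given as an at least 4.5-fold higher number from compound 3 to compound 4 (0.65 log units; beyond the scatter). Compound 4 is estimated at 45 mL.min-1.g-1, with an expected range of 14 mL.min-1.g-1 to 140 mL.min-1.g-1.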

Compound 4, intrinsic clearance in microsomes: 449 mL.min-1.g-1
Compound 4: the middle estimate sits 10-fold (1.00 log units) below what was measured; the measured number lies above the stated range.
By their numbers in this assay, from the lowest: compound 1; then compound 2; then compound 4. At a limit, below all of these: compound 3.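

In this assay compound 3 gives < 10 mL.min-1.g-1, which is a limit of the assay and not a number. Among the compounds shown here, putting tert-butyl in place of methoxy on this aromatic carbon, between two ring nitrogen atoms and para to a large group, while the rest of the molecule stays the same, gives an at least 44-fold higher number from compound 3 to compound 4 (1.65 log units; beyond the scatter), which shows that this single position can move clearance from the slow end of the assay to a high number, something the earlier compounds could not show, as no two of them differed in only one place. The true size of the step remains unknown on one side because one end of it is not a number: the limit of < 10 mL.min-1.g-1 in this assay, at which 1 of the 4 values shown sits.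

With only these two groups compared at this position, the compounds shown cannot separate the effect of the loss of the oxygen from that of the larger number of heavy atoms. As far as these compounds go, it also remains open how clearance would respond to an isopropyl group or to an amine such as dimethylamino on the same carbon.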